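The source may hold more compounds than are shown below. What is called first, only, known or untested is meant among the compounds shown, and "the series" means these compounds.

In an ADME assay on MT4 cells (Homo sapiens) for cytotoxicity, read by spectrophotometry, with a stated time of 5 days (on this read-out higher numbers stand for lower toxicity in this test and lower numbers for higher toxicity in this test), compound 1 `Cc1ccc2c(c1)/C(=N/NC(=S)NO)C(=O)N2CN1CCN(c2ccccc2)CC1` gives 420000 nM and compound 2 `O=C1/C(=N\NC(=S)NO)c2cc(Cl)ccc2N1CN1CCN(c2ccccc2)CC1` gives 273000 nM. Among the measured compounds shown here, these two numbers lie within the scatter of each other, so on this read-out compound 2 cannot be told apart from the only other measured compound. Compound 3 `O=C1/C(=N\NC(=S)NO)c2cc(F)ccc2N1CN1CCN(c2ccccc2)CC1` keeps the rest of compound 2 and differs at one place: fluoro in place of chloro on an aromatic carbon. For the measured compounds named here, one measured step bears on this swap, chloro in place of methyl on an aromatic carbon, and it came to a 1.5-fold lower number from compound 1 to compound 2 (0.19 log units; within the scatter). As that single step stayed within the scatter, no step beyond the scatter is expected in this assay this time. The expected step is a 1.1-fold higher number from compound 2 to compound 3 (0.04 log units; within the scatter). For compound 3 the estimated value is 300000 nM, with an expected range of 140000 nM to 600000 nM.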

Compound 3, half-maximal cytotoxic concentration: 251000 nM
For compound 3 the middle estimate is 1.2-fold (0.08 log units) above the measured one, and the stated range covers the measured number.
By their numbers in this assay, from the lowest: compounds 3, 2 and 1 (each within the scatter of the next).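

Among the compounds shown here, with fluoro in place of chloro on this aromatic carbon, this assay shows a 1.1-fold lower number from compound 2 to compound 3 (0.04 log units; within the scatter) and so no step that can be told from the scatter. Fluoro in place of methyl gives a 1.7-fold lower number from compound 1 to compound 3 (0.22 log units; within the scatter) and stays within the scatter as well, so methyl, chloro and fluoro at this one place now give numbers that this test cannot separate, which the single earlier step could not show for a third group. No measurement shown offers any explanation for this sameness.

Still open, as far as these compounds go, is whether an amine, a carboxylic acid or a longer chain on this aromatic carbon would give a step beyond the scatter. Also open, from the compounds shown here alone, is whether these same swaps would read alike with a different group elsewhere on the shared core.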